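Swapping a morpholine chain for a trifluoroacetamide: cytotoxicity outlook

The source may hold more compounds than are shown below. What is called first, only, known or untested is meant among the compounds shown, and "the series" means these compounds.

The account follows a quinazoline series tested in an ADME assay on BJ cells (Homo sapiens) for cytotoxicity, with a stated time of 72 h; on this read-out higher numbers stand for an effect only at larger amounts of compound and lower numbers for an effect already at smaller amounts. Compound 1, `Nc1nc(-c2ccccn2)nn1-c1ncnc2ccccc12`, returns a limit of the assay rather than a number, namely > 50000 nM. Compound 2, `COc1cc2ncnc(-n3nc(N)nc3N)c2cc1OC`, likewise reaches only a limit, > 33000 nM. Compound 3, `COc1cc2ncnc(-n3nc(-c4ccccn4)nc3N)c2cc1OCCCN1CC(C)OC(C)C1`, also gives a limit, > 25000 nM, so no numerical value exists for it in this assay; it sits at the limit of > 25000 nM in this assay, at which 1 of the 3 values shown sits, while the other two values sit at the limit of > 33000 nM in this assay, at which 1 of the 3 values shown sits, and (the limit of > 50000 nM in this assay, at which 1 of the 3 values shown sits). Going by the values given here, none of the three compounds shows an effect within the tested range, and no measured step between them can be drawn.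

Compound 4, `COc1cc2ncnc(-n3nc(-c4ccccn4)nc3N)c2cc1OCCCNC(=O)C(F)(F)F`, has not yet been tested. It differs from compound 3 in one place: ((trifluoromethyl)carbonyl)amino in place of 2,6-dimethylmorpholin-4-yl on a saturated chain carbon, three bonds along the chain from an oxygen on an aromatic ring. Since every compound shown has stayed at a limit of this assay, no step beyond the usual scatter is expected from compound 3 to compound 4, and the estimated change is a step that the limit leaves unreadable from compound 3 to compound 4. Compound 4 is therefore expected to give about 30000 nM in this assay, with a range from 10000 nM to 100000 nM, and most likely only a limit will again be reported.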

Compound 4, half-maximal effective concentration: > 7000 nM
Compound 4 was reported as a limit; the forecaster's own chance of this, stated with the estimate: 85%; the middle value is on the limit's open side.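

In this assay compound 4 is reported only as a limit, > 7000 nM. Compound 3 is likewise a limit, > 25000 nM. Going by these compounds alone, no step can therefore be read from compound 3 to compound 4. The compounds shown leave open at what concentration, if any, cytotoxicity appears, and whether ((trifluoromethyl)carbonyl)amino in place of 2,6-dimethylmorpholin-4-yl alters it.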